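This account rests on a few compounds, and the source may have more. Where it says the series, first, only, none or still open, it means among the compounds named here.

Compound 1 `CN(C(=O)NC(=O)c1ccccc1F)c1nc(C(F)(F)F)c(C(=O)N/N=C/c2ccccc2C(F)(F)F)s1` and compound 2 `CN(C(=O)NC(=O)c1ccccc1F)c1nc(C(F)(F)F)c(C(=O)N/N=C/c2cccc(C(F)(F)F)c2)s1` share the same core and differ only in one ring. Going by the values given here, in a functional assay on HeLa cells (Homo sapiens) for inhibition, read by MTT assay, with a stated time of 72 h (on this read-out higher numbers stand for weaker inhibition and lower numbers for stronger inhibition), compound 1 gives 10.1 ug/mL, the lowest of the two numbers so far, while compound 2 gives 19.1 ug/mL; the step of a 1.9-fold higher number from compound 1 to compound 2 (0.28 log units; within the scatter) does not separate the two beyond the scatter of repeated measurements. Compound 3 `CN(C(=O)NC(=O)c1c(Cl)cccc1Cl)c1nc(C(F)(F)F)c(C(=O)N/N=C/c2ccccc2C(F)(F)F)s1` differs from compound 1 by 2,6-dichlorophenyl in place of 2-fluorophenyl on a carbonyl carbon. Among the compounds with values here, the only measured step concerns the ring on the carbon with a double bond to nitrogen, a different place from the carbonyl carbon changed here, so no measured step bears on this change, and there is no basis for expecting a shift in either direction beyond the scatter. Compound 3 is therefore expected to give 10 ug/mL in this assay, within a range from 4 ug/mL to 25 ug/mL, which means an expected step of a 1.0-fold lower number from compound 1 to compound 3 (0.00 log units; within the scatter).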

Compound 3, half-maximal inhibitory concentration: 5.23 ug/mL
The estimate for compound 3 lay 1.9-fold (0.28 log units) above the measured number; the range from low to high includes it.
By their numbers in this assay, from the lowest: compounds 3, 1 and 2 (each within the scatter of the next, the first and the last beyond it).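

Going by these compounds alone, on the carbonyl carbon, a place no earlier step had touched, 2,6-dichlorophenyl in place of 2-fluorophenyl gives in this assay a 1.9-fold lower number from compound 1 to compound 3 (0.29 log units; within the scatter). Within the data shown here, this place therefore accepts the exchange of one of these substituted phenyl rings for the other, with no difference that repeated measurements could separate from scatter, just as the one step on the ring at the other end of the molecule showed for its own change. No measurement on these compounds speaks to what lies behind these numbers. On these data alone, it remains open whether a plain phenyl, a saturated cyclohexyl ring or a small methyl on the same carbonyl carbon would also stay within the scatter. Also open, as far as these compounds go, is whether 2,6-dichlorophenyl would behave the same way alongside 3-(trifluoromethyl)phenyl at the other end.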